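The source may report more compounds than this note shows. Statements on the series, on what has been measured and on what is new or still open speak of the compounds shown alone.

Compound 1 `Cc1nnc(SCc2cc(=O)c3cc(Cl)ccc3o2)o1` gives > 25000 nM in a functional assay on HEp-2 cells (Homo sapiens) for cytotoxicity, read by MTT assay, with a stated time of 72 h (on this read-out lower numbers stand for stronger inhibition and higher numbers for weaker inhibition), which is a limit of the assay. Compound 2 `Cc1ccc2oc(CSc3nnc(C)s3)cc(=O)c2c1` gives > 25000 nM in this assay, likewise only a limit.

Compound 2 therefore stands at the limit, where both values shown sit (the limit of > 25000 nM in this assay, at which 2 of the 2 values shown sit). Compound 3 `Cc1nnc(SCc2cc(=O)c3cc(Cl)ccc3o2)s1` differs from compound 2 by chloro in place of methyl on an aromatic carbon. Among the compounds with values here, no step between measured compounds is available, so the size of this change in this assay cannot be read from the data; no move beyond the scatter is expected. Compound 3 is expected to give 30000 nM, within 15000 nM to 80000 nM, most likely again as a limit. The step from compound 2 to compound 3 is expected to be a step that the limit leaves unreadable from compound 2 to compound 3.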

Compound 3, half-maximal inhibitory concentration: > 25000 nM
Compound 3 ended at the assay's limit (the forecaster's own chance of this, stated with the estimate: 85%); the middle value lies beyond the limit too.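

No step among compound 1, compound 2 and compound 3 can be read, as each value is only a limit: the limit of > 25000 nM in this assay, at which 3 of the 3 values shown sit.

The compounds shown leave open whether either change has any effect in this assay.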